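Amine to Guanidine on a Shared Aryloxypropyl Chain

This account rests on a few compounds, and the source may have more. Where it says the series, first, only, none or still open, it means among the compounds named here.

Of the compounds shown here, three have been measured in an assay on isolated protein for inhibition of Voltage-dependent N-type calcium channel subunit alpha-1B (Rattus norvegicus); on this read-out higher numbers stand for an effect only at larger amounts of compound and lower numbers for an effect already at smaller amounts. Compound 1 `NCCCOc1ccc(CN(C(=O)c2ccccc2OCCCN)c2nc3ccc(Oc4ccc(O)cc4)cc3s2)cc1` gives 3180 nM, compound 2 `NC(N)=NCCCOc1ccc(CNc2nc3ccc(Oc4ccccc4)cc3s2)cc1` gives 5800 nM, and compound 3 `NCCCOc1ccc(CNc2ccc(Oc3ccccc3)cc2)cc1` gives 34000 nM. Among these three, compound 3 stands at the highest number: its gap to compound 2 and its gap to compound 1 both lie beyond the usual scatter, so compound 3 is the weakest of the three on this read-out. For the measured compounds named here, compound 2 and compound 3 differ in more than one place, so no single step between them can be read off.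

Compound 4 `NC(N)=NCCCOc1ccc(CNc2ccc(Oc3ccccc3)cc2)cc1` has not yet been measured. It differs from compound 3 by a group of 4 heavy atoms (1 carbon, 3 nitrogen; no ring) in place of one nitrogen atom, on a saturated chain carbon, three bonds along the chain from an oxygen on an aromatic ring. Going by the values given here, no measured pair shows this change alone. Compound 2 carries the same entering group on a different core and gives 5800 nM, which is only a rough pointer.

For compound 4 a modest step toward lower numbers is expected, a 1.9-fold lower number from compound 3 to compound 4 (0.28 log units; within the scatter), possibly not beyond the scatter. The estimate for compound 4 in this assay is 18000 nM, with a range from 6000 nM to 55000 nM.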

Compound 4, half-maximal effective concentration: 21000 nM
Estimate against measurement, compound 4: 1.2-fold (0.07 log units) below; measured number inside the range.
By their numbers in this assay, from the lowest: compounds 1 and 2 (each within the scatter of the next); then compounds 4 and 3 (each within the scatter of the next).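

In this assay, the group of 4 heavy atoms (1 carbon, 3 nitrogen; no ring) in place of the amino group, on a saturated chain carbon, three bonds along the chain from an oxygen on an aromatic ring, gives a 1.6-fold lower number from compound 3 to compound 4 (0.21 log units; within the scatter). For the compounds shown here, this is the first comparison in this set in which only this one place changes, and it shows that on this core the exchange brings no difference that can be told from the ordinary spread of repeated measurements. The added heavy atoms and the extra hydrogen-bond donor counted for the entering group are thus accommodated at this position without a separable effect on this read-out, and nothing available here bears on why that is so.

The compounds shown leave open whether the same exchange would give a step of similar size on the core of compound 2 or on the core of compound 1. They also leave open whether a dimethylamino group, a carboxylic acid or a longer chain at this place would move the number clearly away from those of compound 3 and compound 4.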